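A few compounds are considered here, and "the series" means these few. Any claim that something is new, unique, unknown or untested is made for them only; others in the source may bear on it.

Compound 1, `O=C(O)COCCCCC1=CCC[C@@H]1NS(=O)(=O)c1ccc(Cl)c(Cl)c1`, gives 1900 nM in a functional assay on a cell-free system (plasma) for inhibition of thromboxane A2 receptor (Homo sapiens), read by turbidimetry; on this read-out lower numbers stand for stronger inhibition and higher numbers for weaker inhibition.
Compound 2, `O=C(O)CCC/C=C\C[C@H]1[C@H](F)CC[C@@H]1NS(=O)(=O)c1cccc2cccnc12`, gives 2000 nM in this assay.
Compound 3, `O=C(O)CCC/C=C\C[C@H]1[C@H](F)CC[C@@H]1NS(=O)(=O)c1ccc(Cl)c(Cl)c1`, gives 630 nM in this assay.

Among these three numbers compound 1 stands second highest. Compound 2 lies so close to compound 1 that the two cannot be told apart within the usual scatter, whereas compound 3 sits clearly lower, a gap beyond the scatter. Compound 4, `Cc1ccc(S(=O)(=O)N[C@H]2CCC=C2CCCCOCC(=O)O)cc1`, has not yet been measured. It differs from compound 1 in a single place: 4-methylphenyl in place of 3,4-dichlorophenyl on a sulfonyl sulfur. Among the measured compounds shown here, no measured pair here shows what this particular exchange does, so the expectation rests on the measured numbers and the size of the change alone. For the measured compounds named here, since the sulfonyl group is the only part that changes and the rest of compound 1 stays untouched, a modest step toward a higher number is expected, likely just beyond the scatter rather than a large shift. Compound 4 is therefore estimated to give 4000 nM, within a range from 1500 nM to 12000 nM. This estimate means an expected step of a 2.1-fold higher number from compound 1 to compound 4 (0.32 log units; beyond the scatter).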

Compound 4, half-maximal inhibitory concentration: 1900 nM
Compound 4: the middle estimate sits 2.1-fold (0.32 log units) above what was measured; the range from low to high includes it.
By their numbers in this assay, from the lowest: compound 3; then compounds 1, 4 and 2 (each within the scatter of the next).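

Putting 4-methylphenyl in place of 3,4-dichlorophenyl on the sulfonyl sulfur gives no change at the digits printed from compound 1 to compound 4 (within the scatter) in this assay on the core of compound 1. Among the compounds shown here, this is the first direct reading at this position with the rest of the molecule held fixed. It shows that, on this core, the two chlorine atoms are not required to keep the value, since a single methyl group on the ring serves equally well in this read-out. Nothing measured explains why the two groups match. Still open, from the compounds shown here alone, is whether a plain phenyl or a 4-methoxyphenyl group on the sulfonyl sulfur would also match these two. Also open, going by these compounds, is whether 4-methylphenyl would match 3,4-dichlorophenyl on the fluorine-bearing core of compound 3.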